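Three Limits and a Smaller Group on the Ring Nitrogen

This account rests on a few compounds, and the source may have more. Where it says the series, first, only, none or still open, it means among the compounds named here.

Three compounds share one core and differ only in the group on an amine nitrogen in a ring. Compound 1 `CCCn1c(=O)[nH]c2nc(-c3ccc(S(=O)(=O)N4CCN(c5cccc(Br)c5)CC4)cc3)[nH]c2c1=O` carries a 3-bromophenyl there, compound 2 `CCCn1c(=O)[nH]c2nc(-c3ccc(S(=O)(=O)N4CCN(c5ccc(Cl)cc5F)CC4)cc3)[nH]c2c1=O` a 4-chloro-2-fluorophenyl, and compound 3 `CCCn1c(=O)[nH]c2nc(-c3ccc(S(=O)(=O)N4CCN(Cc5ccc(Br)c(F)c5)CC4)cc3)[nH]c2c1=O` a 4-bromo-3-fluorobenzyl. In an assay on CHO cells for displacement of a labelled ligand from adenosine receptor A3 (Homo sapiens), read by scintillation counting, with a stated time of 45 min, in the presence of a further agent that is not named here (a higher number here means a weaker inhibitor, a lower number a stronger inhibitor), compound 1 gives > 1000 nM, which is a limit of the assay rather than a number. Compound 2 gives > 1000 nM in this assay, again a limit. Compound 3 likewise gives only a limit, > 1000 nM, in this assay. Compound 3 thus stands exactly where every measured value stands: the limit of > 1000 nM in this assay, at which 3 of the 3 values shown sit. The steps a step that the two limits leave unreadable from compound 1 to compound 2, a step that the two limits leave unreadable from compound 1 to compound 3 and a step that the two limits leave unreadable from compound 2 to compound 3 can therefore be read neither in size nor in direction.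

Compound 4 `CCCn1c(=O)[nH]c2nc(-c3ccc(S(=O)(=O)N4CCN(c5ccccc5F)CC4)cc3)[nH]c2c1=O` is the unmeasured analogue, changed as follows: 2-fluorophenyl in place of 4-bromo-3-fluorobenzyl on an amine nitrogen in a ring. Going by the values given here, the three unreadable steps are the only evidence bearing on this change, and they show only that none of the three groups brought binding into the measurable range. No step beyond the scatter can be expected from them in this assay, in either direction. The expected step is a step that the limit leaves unreadable from compound 3 to compound 4. Compound 4 is accordingly estimated at 3000 nM, within a range from 800 nM to 20000 nM, most likely again reported only as a limit.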

Compound 4, inhibition constant: > 1000 nM
Compound 4: a limit, no number; the forecaster's own chance of this, stated with the estimate: 80%; the middle value is on the limit's open side.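

In this assay compound 4 gives > 1000 nM, again a limit of the assay and not a number. Its steps from compound 1, compound 2 and compound 3 therefore cannot be read, in size or in direction: the limit of > 1000 nM in this assay, at which 4 of the 4 values shown sit. The compounds shown leave open whether any group on this amine nitrogen in a ring would bring binding into the measurable range.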